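The source may report more compounds than this note shows. Statements on the series, on what has been measured and on what is new or still open speak of the compounds shown alone.

Of the compounds shown here, two built on the same core have so far been measured in a physicochemical assay for lipophilicity, read by HPLC, at pH 7.5; a lower number here means a more polar compound, a higher number a more lipophilic compound. Compound 1 `CCOc1ccccc1-c1ccc(-c2nc3cnccc3c(N[C@H](CC)C(=O)N(C)C)c2C#N)cc1` gives 3.7. Compound 2 `CC[C@@H](Nc1c(C#N)c(-c2ccc(-c3ccccc3N(C)C)cc2)nc2cnccc12)C(N)=O` gives 3.2, the lower of the two numbers, with compound 1 standing higher by a margin beyond the usual scatter. Compound 3 `CC[C@@H](Nc1c(C#N)c(-c2ccc(-c3cccc(OC)c3)cc2)nc2cnccc12)C(N)=O` awaits measurement. Going by the values given here, it differs from compound 2 in a single place: 3-methoxyphenyl in place of 2-(dimethylamino)phenyl on an aromatic carbon No measured step guides this exchange. The expectation is a small shift in this assay, if any, and more likely downward than upward, so that a number 0.20 log units lower from compound 2 to compound 3 (within the scatter) is expected to stay within the scatter. Compound 3 is accordingly estimated at 3, within a range from 2.6 to 3.4.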

Compound 3, distribution coefficient: 2.7
The estimate for compound 3 lay 0.30 log units above the measured number; low and high end bracket the measured number.
By their numbers in this assay, from the lowest: compound 3; then compound 2; then compound 1.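

In this assay, placing 3-methoxyphenyl in place of 2-(dimethylamino)phenyl gives a number 0.50 log units lower from compound 2 to compound 3 (beyond the scatter) with the rest of the molecule unchanged. The group on this aromatic carbon, para to a large group, can therefore move the number on its own. Nothing measured here explains the shift.

The two groups differ both in their substituent and in where it sits on the ring, and the compounds shown do not separate these two changes. Going by these compounds, how a phenyl ring bearing a carboxylic acid or a longer chain would read in this assay also remains open.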